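A Furan Swapped at the Assay's Limit

The source may report more compounds than this note shows. Statements on the series, on what has been measured and on what is new or still open speak of the compounds shown alone.

In a functional assay on RAW264.7 cells (Mus musculus) for inhibition, read by Griess assay, with stated times of 2 h and 18 h (on this read-out lower numbers stand for stronger inhibition and higher numbers for weaker inhibition), compound 1, `CC1=C(CCc2ccoc2)[C@@]2(C)CC[C@@H](O)C(C)(C)[C@@H]2[C@H](O)C1=O`, gives > 50000 nM, which is a limit of the assay and not a number. Compound 2, `CC1=C(CCc2ccoc2)[C@@]2(C)CCCC(C)(C)[C@@H]2[C@H](O)C1=O`, gives > 50000 nM, which is also a limit. Compound 3, `COC1C=C(CCC2=C(C)C(=O)[C@@H](O)[C@H]3C(C)(C)[C@H](O)CC[C@]23C)C(=O)O1`, keeps the core of compound 1 but exchanges the furan-3-yl group: a group of 8 heavy atoms (5 carbon, 3 oxygen; one five-membered non-aromatic ring with 1 hetero atom) in place of a group of 5 heavy atoms (4 carbon, 1 oxygen; one five-membered aromatic ring with 1 hetero atom), on a saturated chain carbon, two bonds along the chain from a double-bonded ring carbon.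

Within the data shown here, the only measured step, a step that the two limits leave unreadable from compound 1 to compound 2, concerns another change, hydrogen in place of hydroxy on a saturated ring carbon. It offers no size to carry over to the new group. Without a readable guide, a large change in this assay is not expected, and compound 3 may well stay at the limit. If a number does appear, the expected result is an at least 1.2-fold lower number from compound 1 to compound 3 (0.09 log units; that floor lies within the scatter), towards slightly stronger inhibition. Compound 3 is estimated at 40000 nM, with an expected range of 12000 nM to 80000 nM.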

Compound 3, half-maximal inhibitory concentration: 27500 nM
For compound 3 the middle estimate is 1.5-fold (0.16 log units) above the measured one; low and high end bracket the measured number.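

In this assay, placing the new five-membered non-aromatic ring on the chain in place of furan-3-yl gives an at least 1.8-fold lower number from compound 1 to compound 3 (0.25 log units; that floor lies within the scatter). Compound 3 is the only compound shown with a real number, so this position is the one place where a change has been seen to bring a value inside the range of the assay. Even so, the true size of the step stays unknown because its starting point is a limit, and the step between the other two compounds cannot be read at all: the limit of > 50000 nM in this assay, at which 2 of the 3 values shown sit.

Going by these compounds, it remains open which part of the entering group matters, and whether an open chain ending in a carboxylic acid or an amine at the same place would do as well as the ring. Also open, on these data alone, is whether hydrogen in place of hydroxy on a saturated ring carbon would change the number of compound 3.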